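Taking the Phenyl Off Compound 1

This account rests on a few compounds, and the source may have more. Where it says the series, first, only, none or still open, it means among the compounds named here.

Measured so far in a functional assay on HeLa cells (Homo sapiens) for antiproliferative activity, read by sulforhodamine B assay, with a stated time of 72 h; on this read-out lower numbers stand for stronger inhibition and higher numbers for weaker inhibition:
compound 1 `O=C1CS/C(=N/Nc2nncc3ccccc23)N1c1ccccc1` gives 56 nM here
compound 2 `Clc1ccc(C(/C=C/c2ccccc2)=N\Nc2nncc3ccccc23)cc1` gives 3.3 nM here
compound 3 `COc1ccc(NC(=S)NNc2nncc3ccccc23)cc1` gives 38 nM here

Compound 1 and compound 3 sit within the usual scatter of each other, while compound 2 has a clearly lower number, beyond that scatter. The next compound to be tested is compound 4 `O=C1CS/C(=N/Nc2nncc3ccccc23)N1`, which has hydrogen in place of phenyl on an amide-type nitrogen in a ring of the core of compound 1. Compound 1, compound 2 and compound 3 each carry a six-membered aromatic ring of carbon only besides the shared core, and compound 4 has none. Going by the values given here, no measured pair shows this change on its own, so the expectation is uncertain. Starting from compound 1 at 56 nM in this assay, a modest move towards a higher number is expected. The estimated step is a 2.1-fold higher number from compound 1 to compound 4 (0.33 log units; beyond the scatter) and it points to weaker inhibition. The estimate for compound 4 is 120 nM with a range of 25 nM to 600 nM until it is measured.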

Compound 4, half-maximal inhibitory concentration: 57 nM
For compound 4 the middle estimate is 2.1-fold (0.32 log units) above the measured one, and the stated range covers the measured number.
By their numbers in this assay, from the lowest: compound 2; then compounds 3, 1 and 4 (each within the scatter of the next).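

In this assay, hydrogen in place of phenyl on the amide-type nitrogen in a ring gives a 1.0-fold higher number from compound 1 to compound 4 (0.01 log units; within the scatter), so this read-out does not separate the two compounds. The earlier compounds shown here each carried a six-membered aromatic ring of carbon only besides the shared core, so they could not show whether such a ring matters, whereas compound 4 has none and gives 57 nM. Nothing available here offers a reason for this result.

Going by these compounds, it remains open whether a group of another kind on this same nitrogen, such as a methyl, a longer butyl chain or a chain ending in a carboxylic acid, would move the number in either direction. One step at one position also cannot say whether phenyl can be dropped as freely from any other compound.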